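A few compounds are considered here, and "the series" means these few. Any claim that something is new, unique, unknown or untested is made for them only; others in the source may bear on it.

Measured in a functional assay on HEK293 cells for activation of melanin-concentrating hormone receptor 1 (Rattus norvegicus), read by inositol phosphate accumulation; on this read-out lower numbers stand for an effect already at smaller amounts and higher numbers for an effect only at larger amounts of compound:
compound 1 `O=C(CCc1ccc(C(F)(F)F)cc1)Nc1ccc2nc(N3CCC3)ccc2c1` – 56 nM
compound 2 `CN(c1ccc2cc(NC(=O)CCc3ccc(C(F)(F)F)cc3)ccc2n1)C1CCCC1` – 350 nM
compound 3 `CC(=O)NC1CCN(c2ccc3cc(NC(=O)CCc4ccc(C(F)(F)F)cc4)ccc3n2)C1` – 440 nM

Compound 1 gives the lowest of the three numbers in this assay, and its steps to compound 2 and to compound 3 both lie beyond the scatter. Compound 4 `NC1CCN(c2ccc3cc(NC(=O)CCc4ccc(C(F)(F)F)cc4)ccc3n2)C1` differs from compound 1 in one place: 3-aminopyrrolidin-1-yl in place of azetidin-1-yl on an aromatic carbon. Within the data shown here, two measured steps bear on this change, both enlarging the group on the same aromatic carbon: a 6.3-fold higher number from compound 1 to compound 2 (0.80 log units; beyond the scatter) and a 7.9-fold higher number from compound 1 to compound 3 (0.90 log units; beyond the scatter). Compound 3 carries the closest relative of the incoming group, and compound 2 and compound 3 sit within the scatter of each other: a 1.3-fold higher number from compound 2 to compound 3 (0.10 log units; within the scatter). A modest rise in the number is therefore expected for compound 4, estimated as a 5.7-fold higher number from compound 1 to compound 4 (0.76 log units; beyond the scatter). Compound 4 is estimated at 320 nM, in the range 110 nM to 950 nM.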

Compound 4, half-maximal effective concentration: 200 nM
Compound 4: the middle estimate sits 1.6-fold (0.20 log units) above what was measured; measured number inside the range.
By their numbers in this assay, from the lowest: compound 1; then compounds 4, 2 and 3 (each within the scatter of the next, the first and the last beyond it).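

In this assay, the 3-aminopyrrolidin-1-yl group still gives a higher number than azetidin-1-yl (a 3.6-fold higher number from compound 1 to compound 4 (0.55 log units; beyond the scatter)), so the rise seen with the larger groups on this aromatic carbon also holds for a group with a free amine. The acetyl on that amine counts as well: hydrogen in its place gives a lower number (a 2.2-fold lower number from compound 3 to compound 4 (0.34 log units; beyond the scatter)), while the step to cyclopentyl(methyl)amino (a 1.8-fold lower number from compound 2 to compound 4 (0.24 log units; within the scatter)) sets no order between those two groups. Nothing measured here explains these differences.

Going by these compounds, whether an amine on the smaller ring, as in 3-aminoazetidin-1-yl, would keep the low number of compound 1 stays open. So does the effect of a hydroxyl or a dimethylamino group in place of the amine on the pyrrolidine.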